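This account rests on a few compounds, and the source may have more. Where it says the series, first, only, none or still open, it means among the compounds named here.

Measured so far:
compound 1, `CC(C)(C)OC(=O)N[C@@H](CCCCS)C(=O)NC1CCCC1`: 50%
compound 2, `O=C(O)CCCC[C@H](NC(=O)OCc1ccccc1)C(=O)NC1CCCC1`: 20%

In an assay on isolated protein for inhibition of protein deacetylase HDAC6 (Homo sapiens), read by fluorescence, tested at 1 uM (on this read-out lower numbers stand for less inhibition and higher numbers for more inhibition at the one concentration tested (going by the name of the read-out)), compound 1 gives 50%, the higher of the two numbers; compound 2 gives 20%, lower by a margin beyond the usual scatter. Compound 3, `COC(=O)CCCCC[C@H](NC(=O)OC(C)(C)C)C(=O)NC1CCCC1`, has not been measured. It differs from compound 1 by (methoxycarbonyl)methyl in place of sulfanyl on a saturated chain carbon, five bonds along the chain from an amide-type nitrogen and a carbonyl carbon. Among the measured compounds shown here, no pair of measured compounds shares this change, so no measured step shows how large its effect is. For the measured compounds named here, the only guide is that compound 2, whose chain ends in a carboxylic acid instead of a sulfanyl group, sits clearly lower than compound 1 in this assay. Because compound 2 gives 20%, a downward step beyond the scatter is expected, a number 35 percentage points lower from compound 1 to compound 3 (beyond the scatter). For compound 3 the expected value is 15%, with a range from 0% to 35%.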

Compound 3, a percentage reported as inhibition, at one concentration (the size of the read-out at that concentration, not a potency): 60%
Estimate against measurement, compound 3: 45 percentage points below; measured number above the stated range.
By their numbers in this assay, from the lowest: compound 2; then compounds 1 and 3 (each within the scatter of the next).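

In this assay, (methoxycarbonyl)methyl in place of sulfanyl gives a number 10 percentage points higher from compound 1 to compound 3 (within the scatter), so the two compounds cannot be told apart at the one concentration tested. At this place, on a saturated chain carbon, five bonds along the chain from an amide-type nitrogen and a carbonyl carbon, sulfanyl is therefore not required for this level of inhibition, as a quite different group serves equally well on the shared core. Nothing available explains why these two groups read alike.

A single concentration also leaves open whether compound 1 and compound 3 would still match in a full potency measurement. As far as these compounds go, how a hydroxamic acid or an amine would read at this place, with the rest of compound 1 unchanged, also remains open.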